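This account rests on a few compounds, and the source may have more. Where it says the series, first, only, none or still open, it means among the compounds named here.

Compound 1 `Cc1ccc(C(=O)N/N=C/c2ccccc2)c(O)c1` carries an unsubstituted ring at the hydrazone end. In a functional assay (Mus musculus, strain BALB/C) for inhibition, read by MTT assay, with stated times of 24 h and 72 h (a higher number here means a weaker inhibitor, a lower number a stronger inhibitor), compound 1 gives 53900 nM. Compound 2 `Cc1ccc(C(=O)N/N=C/c2cccc(Cl)c2)c(O)c1` bears a chloro group on that ring, and in this assay compound 2 gives 24400 nM. Compound 3 `Cc1ccc(C(=O)N/N=C/c2cccc(F)c2)c(O)c1` bears a fluoro group in the same place, and in this assay compound 3 gives 31200 nM. Among these three numbers compound 3 stands second highest: its nearest neighbour is compound 2, and the gap between them, a 1.3-fold higher number from compound 2 to compound 3 (0.11 log units; within the scatter), lies within the scatter; compound 1 lies furthest away, and a 1.7-fold lower number from compound 1 to compound 3 (0.24 log units; within the scatter) is also within the scatter.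

Compound 4 `Cc1ccc(C(=O)N/N=C/c2cccc(Br)c2)c(O)c1` differs from compound 3 in one place: bromo in place of fluoro on an aromatic carbon. Among the measured compounds shown here, two measured steps bear on this change. a 2.2-fold lower number from compound 1 to compound 2 (0.34 log units; beyond the scatter) shows that a chloro group on this ring brought the number modestly down, while a 1.3-fold higher number from compound 2 to compound 3 (0.11 log units; within the scatter) shows that fluoro and chloro gave numbers within the scatter of each other. The three analogues thus occupy only a narrow band in this assay. Given a 2.2-fold lower number from compound 1 to compound 2 (0.34 log units; beyond the scatter) and a 1.3-fold higher number from compound 2 to compound 3 (0.11 log units; within the scatter), the expected step is small and downward, at most at the edge of the scatter: a 1.4-fold lower number from compound 3 to compound 4 (0.15 log units; within the scatter). Compound 4 is therefore estimated at 22000 nM in this assay, with a range from 9000 nM to 55000 nM.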

Compound 4, half-maximal inhibitory concentration: 28300 nM
Beside the measured number, compound 4's estimate is 1.3-fold (0.11 log units) below it, and the stated range covers the measured number.
By their numbers in this assay, from the lowest: compounds 2, 4, 3 and 1 (each within the scatter of the next, the first and the last beyond it).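

With bromo, a third halogen at this place on the ring stays in the same narrow band in this assay: a 1.1-fold lower number from compound 3 to compound 4 (0.04 log units; within the scatter) and a 1.2-fold higher number from compound 2 to compound 4 (0.06 log units; within the scatter) are both within the scatter, so compound 2, compound 3 and compound 4 show no order among chloro, fluoro and bromo. Against the unsubstituted compound 1, the bromo step also stays within the scatter, at a 1.9-fold lower number from compound 1 to compound 4 (0.28 log units; within the scatter), which leaves a 2.2-fold lower number from compound 1 to compound 2 (0.34 log units; beyond the scatter) as the only step from hydrogen to a halogen here that goes beyond it, even though compound 2 cannot be told apart from compound 4 or compound 3. No measurement is at hand that accounts for this likeness among the halogens.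

The compounds shown leave open whether a group of another kind at this place, such as methoxy, an amine or a carboxylic acid, would move the number out of this band in either direction. They also leave open whether a halogen elsewhere on this ring, or a change to the hydroxyl or methyl group on the other ring, would matter more than the choice among these halogens.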